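A few compounds are considered here, and "the series" means these few. Any claim that something is new, unique, unknown or untested is made for them only; others in the source may bear on it.

Going by the values given here, compound 2 `Nc1c2c(=O)[nH]c(-c3ccccc3)cc2nn1-c1ccccc1` stands at the bottom of the two numbers measured so far: in an assay on isolated protein for inhibition of protein kinase C zeta type (Homo sapiens), read by mobility shift assay, tested at 30 uM (a higher number here means more inhibition at the concentration tested (going by the name of the read-out), a lower number less inhibition), compound 2 gives -163%, while compound 1 `COCCNc1nc(-c2ccccc2)cc2c1c(N)nn2C` gives 20%, a gap beyond the scatter. Compound 3 `COc1ccccc1-c1cc2nn(-c3ccccc3)c(N)c2c(=O)[nH]1` differs from compound 2 by methoxy in place of hydrogen on an aromatic carbon. Among the compounds with values here, no pair of measured compounds shows this change, so nothing indicates its size. The negative reading of compound 2 is expected to carry over, with the step of a number 23 percentage points higher from compound 2 to compound 3 (beyond the scatter) expected to stay within the scatter. For compound 3 the estimate in this assay is -140%, within a range from -220% to -40%.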

Compound 3, a percentage reported as inhibition, at one concentration (the size of the read-out at that concentration, not a potency): 4%
Compound 3: middle estimate off by 144 percentage points, on the low side; the whole stated range lies below it.
By their numbers in this assay, from the lowest: compound 2; then compound 3; then compound 1.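

In this assay methoxy in place of hydrogen, on an aromatic carbon ortho to a large group, gives a large step, a number 167 percentage points higher from compound 2 to compound 3 (beyond the scatter). This position is therefore not indifferent to substitution: the change from phenyl to 2-methoxyphenyl alone removes the strongly negative reading of compound 2. Nothing measured here explains the size of this step.

The compounds shown leave open whether the step is particular to methoxy or would also appear with an amine, a hydroxyl or a longer alkoxy chain at this place. They also leave open whether methoxy would give a similar step elsewhere on this aromatic ring.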